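A few compounds are considered here, and "the series" means these few. Any claim that something is new, unique, unknown or untested is made for them only; others in the source may bear on it.

Measured in a functional assay on WI-38 VA13 cells (Homo sapiens) for cytotoxicity; a higher number here means that more compound is needed for the effect, a lower number that less compound is needed:
- compound 1 `Cc1nc(C)c(C(=O)Nc2ccc3nc(NC(=O)C4CCCCC4)sc3c2)s1`: 0.39 ug/mL
- compound 2 `CC(C)CC(=O)Nc1nc2ccc(NC(=O)c3c(Cl)cccc3Cl)cc2s1`: 0.012 ug/mL

Compound 2 has the lower number of the two, and its gap to compound 1 lies beyond the scatter. Compound 3 `CC(C)OC(=O)Nc1nc2ccc(NC(=O)c3c(Cl)cccc3Cl)cc2s1` carries isopropoxy in place of isobutyl on a carbonyl carbon. Within the data shown here, no measured pair shows this change, so the expectation rests only on compound 2 at 0.012 ug/mL. A small rise in the number in this assay is expected, near the edge of the scatter: a 2.5-fold higher number from compound 2 to compound 3 (0.40 log units; beyond the scatter). The estimate for compound 3 is 0.03 ug/mL, with an expected range of 0.008 ug/mL to 0.12 ug/mL.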

Compound 3, half-maximal effective concentration: 0.0026 ug/mL
The estimate for compound 3 lay 12-fold (1.06 log units) above the measured number, and the stated range ends above it.
By their numbers in this assay, from the lowest: compound 3; then compound 2; then compound 1.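

In this assay, isopropoxy in place of isobutyl on a carbonyl carbon gives a 4.6-fold lower number from compound 2 to compound 3 (0.66 log units; beyond the scatter). Among these compounds, this is the first single-place comparison: it shows that the number responds to this position, and that the (isopropoxycarbonyl)amino group is accepted there without loss of cytotoxic effect. Nothing on hand accounts for the step.

Going by these compounds, whether a longer chain on the oxygen, such as butoxy, or an amine on the same carbonyl carbon would move the number further remains open. So does whether the step carries over to the other amide of compound 1.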